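A few compounds are considered here, and "the series" means these few. Any claim that something is new, unique, unknown or untested is made for them only; others in the source may bear on it.

In an assay on IM-9 cells for binding affinity to Substance-P receptor (Homo sapiens) (a higher number here means a weaker inhibitor, a lower number a stronger inhibitor), compound 2 `Cc1ccccc1-c1c(C(=O)N(C)Cc2ccccc2)n(C)c(=O)c2ccccc12` gives 34 nM, and the only other number shown, from compound 1 `Cc1cc(C)cc(CN(C)C(=O)c2c(-c3ccccc3C)c3ccccc3c(=O)n2C)c1` at 32 nM, lies within the scatter of it, so compound 2 stands alongside compound 1 rather than apart. Among the compounds with values here, the single measured step, a 1.1-fold higher number from compound 1 to compound 2 (0.03 log units; within the scatter), shows that exchanging the 3,5-dimethylphenyl for phenyl on the saturated chain carbon bound to the amide-type nitrogen left the number essentially flat. Compound 3 `COc1ccccc1CN(C)C(=O)c1c(-c2ccccc2C)c2ccccc2c(=O)n1C` carries methoxy in place of hydrogen on an aromatic carbon, sitting ortho to a large group. Within the data shown here, with only that one flat step to lean on, no change beyond the scatter is expected from compound 2 to compound 3 a 1.1-fold lower number from compound 2 to compound 3 (0.03 log units; within the scatter). Compound 3 is therefore estimated at 32 nM, within 15 nM to 70 nM.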

Compound 3, half-maximal inhibitory concentration: 16 nM
Beside the measured number, compound 3's estimate is 2.0-fold (0.30 log units) above it, within the range that was stated.
By their numbers in this assay, from the lowest: compounds 3, 1 and 2 (each within the scatter of the next, the first and the last beyond it).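

Within the data shown here, putting a methoxy on the benzyl group, which turns it into 2-methoxybenzyl, gives the only step beyond the scatter so far in this assay: a 2.1-fold lower number from compound 2 to compound 3 (0.33 log units; beyond the scatter), a modest change. Against the 3,5-dimethylphenyl group, the 2-methoxyphenyl group gives a 2.0-fold lower number from compound 1 to compound 3 (0.30 log units; within the scatter), which stays within the scatter, so these two groups cannot be separated. Nothing available explains the effect of the methoxy. On these data alone, it remains open whether an ethoxy, a chlorine or an amine on this same aromatic carbon would match the methoxy.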